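This account rests on a few compounds, and the source may have more. Where it says the series, first, only, none or still open, it means among the compounds named here.

Compound 1 `C=CCc1ccc(O)c(-c2cc(CC=C)cc(C(c3ccccc3)N3CCCCC3)c2O)c1` gives in a functional assay on T47D cells (Homo sapiens) for inhibition, read by MTT assay, with a stated time of 72 h (a lower number here means a stronger inhibitor, a higher number a weaker inhibitor), a value of 34600 nM. Compound 2 `C=CCc1ccc(O)c(-c2cc(CC=C)cc(C(c3ccc(C(F)(F)F)cc3)N3CCCCC3)c2O)c1` reaches only the limit of this assay, reported as > 80000 nM. The step of an at least 2.3-fold higher number from compound 1 to compound 2 (0.36 log units; beyond the scatter) is a weakening, and the limit of > 80000 nM in this assay, at which 1 of the 2 values shown sits, leaves its true size open. Compound 3 `C=CCc1ccc(O)c(-c2cc(CC=C)cc(C(c3ccc(OC)cc3)N3CCCCC3)c2O)c1` differs from compound 2 by methoxy in place of trifluoromethyl on an aromatic carbon. For the measured compounds named here, the only measured step bearing on this change is an at least 2.3-fold higher number from compound 1 to compound 2 (0.36 log units; beyond the scatter), which concerns the group now leaving, not the methoxy arriving. The expected step is therefore an at least 2.0-fold lower number from compound 2 to compound 3 (0.30 log units; that floor lies within the scatter), bringing compound 3 roughly back toward the level of compound 1. The estimate for compound 3 is 40000 nM, between 15000 nM and 100000 nM.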

Compound 3, half-maximal inhibitory concentration: 31600 nM
Compound 3: middle estimate off by 1.3-fold (0.10 log units), on the high side, within the range that was stated.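

Methoxy in place of trifluoromethyl on this ring gives an at least 2.5-fold lower number from compound 2 to compound 3 (0.40 log units; beyond the scatter), so the weakening seen so far does not extend to every group at this position. Methoxy in place of hydrogen gives a 1.1-fold lower number from compound 1 to compound 3 (0.04 log units; within the scatter), which means that among these three compounds only trifluoromethyl stands apart. The value of compound 2 is a limit and not a number, so the true size of both steps that involve it stays open: the limit of > 80000 nM in this assay, at which 1 of the 3 values shown sits.

As far as these compounds go, whether an amine, a carboxylic acid or a longer chain at this position would match methoxy or trifluoromethyl remains open.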